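The compounds below may be only part of what the source reports. "The series", "measured", "known", "first", "only" and "open" are said of these compounds alone.

In a functional assay on HCT-116 cells (Homo sapiens) for inhibition, read by MTT assay, with a stated time of 48 h (a lower number here means a stronger inhibitor, a higher number a weaker inhibitor), compound 1 `Cc1nc(N(C)c2ccc([Se]C#N)c(C)c2)c2ccccc2n1` gives 13 nM while compound 2 `COc1ccc(N(C)c2nc(C)nc3ccccc23)cc1C(=O)NCC[Se]C#N` gives 313 nM and compound 3 `Cc1nc(N(C)c2ccc(OCC[Se]C#N)cc2)c2ccccc2n1` gives 2290 nM so compound 2 stands in the middle of the three, beyond the scatter from each. Compound 4 `COc1ccc(N(C)c2nc(C)nc3ccccc23)cc1[Se]C#N` differs from compound 2 by one change a group of 3 heavy atoms (1 carbon, 1 nitrogen, 1 selenium; no ring) in place of a group of 8 heavy atoms (4 carbon, 2 nitrogen, 1 oxygen, 1 selenium; no ring), on an aromatic carbon on an aromatic carbon, ortho to a methoxy group. Within the data shown here, no measured step isolates this change. Among the measured compounds shown here, compound 1 at 13 nM also carries the entering group on an aromatic carbon, so a lower number is expected, though this is the only comparison available. The expected fall beyond the scatter (estimated a 7.8-fold lower number from compound 2 to compound 4 (0.89 log units; beyond the scatter)) rests on that single comparison. The estimate for compound 4 is 40 nM (expected range 10 nM to 200 nM).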

Compound 4, half-maximal inhibitory concentration: 34 nM
Compound 4: middle estimate off by 1.2-fold (0.07 log units), on the high side; the range from low to high includes it.
By their numbers in this assay, from the lowest: compound 1; then compound 4; then compound 2; then compound 3.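

In this assay, placing the group of 3 heavy atoms on the aromatic carbon ortho to a methoxy group, in place of the group of 8 heavy atoms, gives a 9.2-fold lower number from compound 2 to compound 4 (0.96 log units; beyond the scatter). Among these compounds, this is the first single-place step, and it shows that the position responds to this change. Nothing available accounts for the size of the step.

From the compounds shown here alone, whether the amide or the chain length matters remains open, and a simple ethyl chain ending in the same selenium group would separate the two. Going by these compounds, how an amine or a carboxylic acid at this position would read is also open.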